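A seven-membered ring enters where compound 2 carries its piperazine

A few compounds are considered here, and "the series" means these few. Any claim that something is new, unique, unknown or untested is made for them only; others in the source may bear on it.

Compound 2 `O=C(Nc1ccc(-c2cnc3cc(N4CCN(C5CC5)CC4)ccn23)cc1)c1ccc([N+](=O)[O-])o1` is the weakest of the two compounds with a number: in a functional assay on AGS cells (Homo sapiens) for antiproliferative activity, read by CCK-8 assay, with a stated time of 72 h (on this read-out higher numbers stand for weaker inhibition and lower numbers for stronger inhibition), compound 2 gives 1920 nM. Compound 1 `CC(=O)N1CC=C(c2ccn3c(-c4ccc(NC(=O)c5ccc([N+](=O)[O-])o5)cc4)cnc3c2)CC1`, which bears an acetyl-substituted tetrahydropyridine at the same carbon, gives 410 nM in this assay, so the step runs a 4.7-fold higher number from compound 1 to compound 2 (0.67 log units; beyond the scatter). Compound 3 `O=C(Nc1ccc(-c2cnc3cc(N4CCC4)ccn23)cc1)c1ccc([N+](=O)[O-])o1`, with azetidin-1-yl in that place, reaches only a limit of the assay and gives > 5000 nM. This is the limit described as the limit of > 5000 nM in this assay, at which 1 of the 3 values shown sits. The steps to it are an at least 2.6-fold higher number from compound 2 to compound 3 (0.41 log units; beyond the scatter) and an at least 12-fold higher number from compound 1 to compound 3 (1.08 log units; beyond the scatter).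

Compound 4 `CN1CCCN(c2ccn3c(-c4ccc(NC(=O)c5ccc([N+](=O)[O-])o5)cc4)cnc3c2)CC1` differs from compound 2 in one place: 4-methyl-1,4-diazepan-1-yl in place of 4-cyclopropylpiperazin-1-yl on an aromatic carbon. The two measured exchanges at this carbon, from compound 1 to compound 2 and from compound 2 to compound 3, were modest and large; both replaced one ring by a quite different one. The exchange in compound 4 keeps a six-membered-like saturated diamine motif with a small alkyl on the distal nitrogen, merely widening the ring, so no step beyond the scatter is expected in either direction. Compound 4 is expected to give 1500 nM in this assay, within a range from 500 nM to 4500 nM. This estimate means the step of a 1.3-fold lower number from compound 2 to compound 4 (0.11 log units; within the scatter).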

Compound 4, half-maximal inhibitory concentration: 2700 nM
Beside the measured number, compound 4's estimate is 1.8-fold (0.26 log units) below it; the measured number falls inside the stated range.
By their numbers in this assay, from the lowest: compound 1; then compounds 2 and 4 (each within the scatter of the next). At a limit, above all of these: compound 3.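

In this assay, the seven-membered ring with its methyl group reads no differently from the six-membered ring with its cyclopropyl group, at a 1.4-fold higher number from compound 2 to compound 4 (0.15 log units; within the scatter), so this carbon does not separate 4-methyl-1,4-diazepan-1-yl from 4-cyclopropylpiperazin-1-yl. The change of ring size and of the small alkyl group together leaves the distance to the acetyl-bearing ring intact, at a 6.6-fold higher number from compound 1 to compound 4 (0.82 log units; beyond the scatter), and both rings with two nitrogens now stand on the same side of compound 1. The comparison with azetidin-1-yl reads only as an at least 1.8-fold lower number from compound 3 to compound 4 (0.26 log units; that floor lies within the scatter), a floor set by a limit of the assay rather than by a number, and that pair stays unseparated: the limit of > 5000 nM in this assay, at which 1 of the 4 values shown sits.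

The compounds shown leave open whether the lower number of compound 1 goes with its acetyl group or with the ring that carries it, and an acetyl group on the seven-membered ring of compound 4 would put that question directly. They also leave open how a morpholin-4-yl group or a piperazine with a free ring nitrogen would read at this carbon.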